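A Methyl-to-Hydrogen Change Tested on a Second Core

The source may hold more compounds than are shown below. What is called first, only, known or untested is meant among the compounds shown, and "the series" means these compounds.

Measured compounds:
compound 1, `Cc1cc(/C=C/c2ccc(O)cc2)[nH]n1`, 45800 nM
compound 2, `COc1ccc(/C=C/c2cc(C)n[nH]2)cc1`, 8400 nM
compound 3, `COc1ccc(/C=C/C(=O)CC(C)=O)cc1`, 9100 nM

The numbers come from a functional assay on DU-145 cells (Homo sapiens) for cytotoxicity, read by MTT assay, with a stated time of 72 h; a lower number here means a stronger inhibitor, a higher number a weaker inhibitor. Compound 2 and compound 1 share a core and differ in one place: hydrogen in place of methyl on an oxygen on an aromatic ring. That change gave a 5.5-fold higher number from compound 2 to compound 1 (0.74 log units; beyond the scatter), so compound 1 is the weaker of the pair. Compound 3 sits on a different core; how the core of compound 3 differs from that of compound 2 is not broken down here. In this assay compound 3 gives a number close to that of compound 2, within the usual scatter, so no order between them can be claimed.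

Compound 4, `CC(=O)CC(=O)/C=C/c1ccc(O)cc1`, has not yet been measured. It differs from compound 3 in exactly the way compound 1 differs from compound 2: hydrogen in place of methyl on an oxygen on an aromatic ring. Because the same change in the other pair gave a 5.5-fold higher number from compound 2 to compound 1 (0.74 log units; beyond the scatter), a step of similar size is expected here, and compound 4 is estimated at a 4.4-fold higher number from compound 3 to compound 4 (0.64 log units; beyond the scatter), resting on this single earlier example. Compound 4 is therefore expected to give 40000 nM, with a plausible span from 15000 nM to 120000 nM.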

Compound 4, half-maximal inhibitory concentration: 8800 nM
Compound 4: the middle estimate sits 4.5-fold (0.66 log units) above what was measured; measured number outside the range, below it.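

In this assay, the swap from methoxy to hydroxy on the core of compound 3 gave a 1.0-fold lower number from compound 3 to compound 4 (0.01 log units; within the scatter), so on this core the two groups cannot be told apart. Set beside the first pair, the same swap did not carry over from one core to the other: the same change on two cores in this assay, a 5.5-fold higher number (0.74 log units; beyond the scatter) from compound 2 to compound 1 and a 1.0-fold lower number (0.01 log units; within the scatter) from compound 3 to compound 4, 5.6-fold (0.75 log units) apart, beyond the scatter of two such steps. This shows that a step measured on one core cannot simply be assumed on the other in this series, but two pairs do not show why the steps differ, which part of either core matters, or what would happen on a further core.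

The compounds shown leave open whether other groups put in place of the methoxy, such as an ethoxy group or an amine, would also behave differently on the two cores. As far as these compounds go, whether the gap between the two steps would hold in other cell lines also remains open.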